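This account rests on a few compounds, and the source may have more. Where it says the series, first, only, none or still open, it means among the compounds named here.

In a functional assay for inhibition, tested at 100 ug/mL (on this read-out lower numbers stand for a weaker effect and higher numbers for a stronger effect at the one concentration tested), compound 3 `Cc1cc(O)c(C(C)C)cc1-c1cc(-c2ccco2)c(C#N)c(=O)[nH]1` gives 70%, the highest of the three numbers measured: compound 2 `COc1ccc(-c2cc(-c3cc(C(C)C)c(O)cc3C)[nH]c(=O)c2C#N)cc1` gives 54% and compound 1 `COc1cccc(-c2cc(-c3cc(C(C)C)c(O)cc3C)[nH]c(=O)c2C#N)c1` gives 49%. The steps of a number 21 percentage points higher from compound 1 to compound 3 (beyond the scatter) and a number 16 percentage points higher from compound 2 to compound 3 (beyond the scatter) both lie beyond the scatter, whereas the step of a number 5 percentage points higher from compound 1 to compound 2 (within the scatter) does not. Compound 4 `Cc1cc(O)c(C(C)C)cc1-c1cc(-c2ccccc2Cl)c(C#N)c(=O)[nH]1` differs from compound 3 by 2-chlorophenyl in place of furan-2-yl on an aromatic carbon. Within the data shown here, the two compounds carrying a methoxyphenyl group gave the lower numbers, so a return to a six-membered aromatic ring of carbon only is expected to give back part of the gain seen for compound 3, although no measured compound carries a chlorine, which widens the uncertainty. For compound 4 a modest fall a number 15 percentage points lower from compound 3 to compound 4 (beyond the scatter) is expected, to an estimated 55% with a range from 40% to 70%.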

Compound 4, a percentage reported as inhibition, at one concentration (the size of the read-out at that concentration, not a potency): 34%
Compound 4: the middle estimate sits 21 percentage points above what was measured; the whole stated range lies above it.
By their numbers in this assay, from the lowest: compound 4; then compounds 1 and 2 (each within the scatter of the next); then compound 3.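

At this position, opposite the ring nitrogen, 2-chlorophenyl gives the lowest number of the four compounds in this assay, with a number 36 percentage points lower from compound 3 to compound 4 (beyond the scatter), a number 20 percentage points lower from compound 2 to compound 4 (beyond the scatter) and a number 15 percentage points lower from compound 1 to compound 4 (beyond the scatter). Six-membered aromatic rings of carbon only therefore do not all give the same number here, so the ring type alone does not set the read-out. No measurement at hand explains this fall.

As far as these compounds go, whether the fall follows the chlorine or its place on the ring remains open; an unsubstituted phenyl or a 4-chlorophenyl group would separate the two. Also open, from the compounds shown here alone, is whether a thiophen-2-yl group would hold the number seen with furan-2-yl.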